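The source may report more compounds than this note shows. Statements on the series, on what has been measured and on what is new or still open speak of the compounds shown alone.

Three compounds have been measured so far:

Compound 1 `CC[C@@H](CCn1cncn1)c1ccccc1` gives 91.2 ug/mL in an ADME assay on RD cells (Homo sapiens) for cytotoxicity, read by MTT assay, with a stated time of 3 days; on this read-out higher numbers stand for lower toxicity in this test and lower numbers for higher toxicity in this test.
Compound 2 `CC[C@@H](CCn1cncn1)c1ccc(Cl)cc1` gives 55.3 ug/mL.
Compound 3 `CC[C@@H](CCn1cncn1)c1ccc(OC)cc1` gives 115 ug/mL.

Among these three numbers, compound 1 stands second highest. Its nearest neighbour is compound 3, which lies within the scatter of it, and its furthest is compound 2, also within the scatter. The new compound 4 `c1ccc(C[C@@H](CCn2cncn2)c2ccccc2)cc1` keeps the shared core and changes one thing: phenyl in place of methyl on a saturated chain carbon, two bonds along the chain from an aromatic carbon.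

The measured steps all concern the aromatic ring rather than the chain: a 1.6-fold lower number from compound 1 to compound 2 (0.22 log units; within the scatter), a 1.3-fold higher number from compound 1 to compound 3 (0.10 log units; within the scatter) and a 2.1-fold higher number from compound 2 to compound 3 (0.32 log units; beyond the scatter). None of them alters the chain where compound 4 differs, so they bear on the new step only loosely. For the measured compounds named here, what they do show is that the series so far sits in a narrow band of values. Going by the values given here, with no closer precedent, the expectation for compound 4 is a step of modest size, a 1.3-fold lower number from compound 1 to compound 4 (0.11 log units; within the scatter), and the estimated value for compound 4 is 70 ug/mL, with a range from 30 ug/mL to 160 ug/mL.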

Compound 4, half-maximal cytotoxic concentration: 56 ug/mL
Compound 4: middle estimate off by 1.3-fold (0.10 log units), on the high side, within the range that was stated.
By their numbers in this assay, from the lowest: compounds 2, 4, 1 and 3 (each within the scatter of the next, the first and the last beyond it).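

For the compounds shown here, this is the first change made on the chain rather than on the aromatic ring, and in this assay it gives a 1.6-fold lower number from compound 1 to compound 4 (0.21 log units; within the scatter). Thus phenyl, with six heavy atoms and an aromatic ring of carbon only, can replace methyl, with one heavy atom, on a saturated chain carbon, two bonds along the chain from an aromatic carbon, without a shift beyond the usual scatter of this test. No measurement at hand explains this outcome.

One bulky carbon-only group cannot show how other groups behave at this place, so an amine, a carboxylic acid or a longer chain such as propyl remains an open case. Also open, from the compounds shown here alone, is whether phenyl here would give a similar result when combined with chloro or methoxy on an aromatic carbon.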